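Swapping the Aryl Substituent on a Bcl-2 Binder Core

The source may hold more compounds than are shown below. What is called first, only, known or untested is meant among the compounds shown, and "the series" means these compounds.

Measured so far in an assay on isolated protein for binding affinity to Apoptosis regulator Bcl-2 (Homo sapiens), read by ELISA; a lower number here means a stronger inhibitor, a higher number a weaker inhibitor:
compound 1 `N#CC1=C2C(=NC1=O)c1cccc3c(Sc4ccc(N)cc4)ccc2c13` gives 331 nM
compound 2 `CCCCCCNC1=C2C(=NC1=O)c1cccc3c(Sc4ccc(N)cc4)ccc2c13` gives 80 nM

Compound 2 stands at the lowest of the two numbers; its nearest neighbour is compound 1, separated by a 4.1-fold lower number from compound 1 to compound 2 (0.62 log units; beyond the scatter), a change of the hexylamino group for the cyano group on the ring carbon. Compound 3 `CCCCCCNC1=C2C(=NC1=O)c1cccc3c(Oc4ccc(C(C)C)cc4)ccc2c13` differs from compound 2 at another place: 4-isopropylphenoxy in place of (4-aminophenyl)sulfanyl on an aromatic carbon. Going by the values given here, no measured step touches this aromatic carbon, so the single known step, from the cyano to the hexylamino group, says nothing directly about it. The expectation must therefore stay broad. Compound 3 is estimated in this assay at 150 nM, with a range from 40 nM to 600 nM. That estimate amounts to an expected step of a 1.9-fold higher number from compound 2 to compound 3 (0.27 log units; within the scatter), which could also fall within the scatter.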

Compound 3, half-maximal inhibitory concentration: 184 nM
Beside the measured number, compound 3's estimate is 1.2-fold (0.09 log units) below it; measured number inside the range.
By their numbers in this assay, from the lowest: compound 2; then compounds 3 and 1 (each within the scatter of the next).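

In this assay, this aromatic carbon of the shared core gives the first read on changing the aryl substituent: replacing (4-aminophenyl)sulfanyl with 4-isopropylphenoxy gives a 2.3-fold higher number from compound 2 to compound 3 (0.36 log units; beyond the scatter), a modest step with the hexylamino group left unchanged. So the position responds to this swap, yet the larger 4-isopropylphenoxy group, which has no hydrogen-bond donor, still leaves a measurable inhibitor in this series. Nothing shown accounts for the size or direction of the step.

On these data alone, the swap changes the sulfur link to oxygen and the amino group to isopropyl at once, so the share of each remains open, and a 4-aminophenoxy or a (4-isopropylphenyl)sulfanyl group would separate them. Also open, as far as these compounds go, is whether the step would hold with a nitrile in place of the hexylamino group.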